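The compounds below may be only part of what the source reports. "The series", "measured", "known", "first", "only" and "open" are said of these compounds alone.

Measured so far in a functional assay on HeLa cells (Homo sapiens) for antiproliferative activity, read by MTT assay, with a stated time of 72 h; on this read-out higher numbers stand for weaker inhibition and lower numbers for stronger inhibition:
Compound 1 `COc1ccc(-c2ncnn2-c2cc(OC)c(OC)c(OC)c2)cc1`: 280 nM
Compound 2 `COc1cc(-c2ncnn2-c2ccc(F)cc2)cc(OC)c1OC`: > 10000 nM
Compound 3 `COc1cc(-n2ncnc2-c2ccccc2)cc(OC)c1OC`: > 10000 nM

Compound 2 stands at the limit of > 10000 nM in this assay, at which 2 of the 3 values shown sit. Its > 10000 nM is a limit of the assay and not a number. Compound 3 gives > 10000 nM, which is also a limit.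

Compound 4 `COc1ccc(-n2ncnc2-c2cc(OC)c(OC)c(OC)c2)cc1` differs from compound 2 as follows: methoxy in place of fluoro on an aromatic carbon. In words, this is methoxy in place of fluoro on an aromatic carbon, para to a large group.

Among the measured compounds shown here, one measured step bears on this change: an at least 35-fold higher number from compound 1 to compound 3 (1.55 log units; beyond the scatter), where hydrogen takes the place of methoxy. That large loss of activity suggests that methoxy can matter here, so a sizeable move to a lower number is expected in this assay. The support is loose, as that step involved hydrogen rather than fluoro and came from a different pair of compounds. The expected change is an at least 6.6-fold lower number from compound 2 to compound 4 (0.82 log units; beyond the scatter). For compound 4 the estimated value is 1500 nM, with an expected range from 150 nM to 10000 nM.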

Compound 4, half-maximal inhibitory concentration: > 10000 nM
Compound 4: only a limit was reported; the forecaster's own chance of this, stated with the estimate: 30%; middle value at least 6.6-fold (0.82 log units) from the limit.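

In this assay, among the compounds shown here, compound 2 and compound 4 both stop at a limit rather than a number, so no step between them can be read: the limit of > 10000 nM in this assay, at which 3 of the 4 values shown sit.
Going by these compounds, whether methoxy in place of fluoro changes activity in this pair at all stays open, as does how far either compound lies beyond that limit.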